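The source may hold more compounds than are shown below. What is called first, only, known or untested is meant among the compounds shown, and "the series" means these compounds.

Compound 2, `CC1(C)N=C(N)N=C(N)N1c1ccc(CCCCc2ccccc2S(=O)(=O)F)c(Cl)c1`, stands highest of the two numbers in an assay on isolated protein for inhibition of Dihydrofolate reductase (Mus musculus) (on this read-out lower numbers stand for lower potency and higher numbers for higher potency (the scale is a negative logarithm)), where compound 2 gives 7.77. Its nearest neighbour is compound 1, `CC1(C)N=C(N)N=C(N)N1c1ccc(CCCCc2cc(Cl)ccc2S(=O)(=O)F)c(Cl)c1`, which in this assay gives 7.06. Going by the values given here, the one measured step, a number 0.71 log units higher from compound 1 to compound 2 (beyond the scatter), came from the single exchange of hydrogen in place of chloro on an aromatic carbon. Compound 3, `CC1(C)N=C(N)N=C(N)N1c1ccc(CCCCc2cccc(Cl)c2S(=O)(=O)F)c(Cl)c1`, reverses the sense of that exchange at a different position: chloro in place of hydrogen on an aromatic carbon. The measured step bears on this only by analogy, since it removed a chloro and gained potency, whereas here a chloro is introduced. On that basis a modest loss relative to compound 2 is the most reasonable expectation, though the different position leaves the size uncertain. Compound 3 is therefore expected to fall by a number 0.47 log units lower from compound 2 to compound 3 (beyond the scatter) in this assay, to an estimated 7.3, within a range of 6.7 to 7.9.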

Compound 3, logarithm of the reciprocal of the active concentration, log(1/C): 8.2
Compound 3: middle estimate off by 0.90 log units, on the low side; the measured number lies above the stated range.
By their numbers in this assay, from the lowest: compound 1; then compound 2; then compound 3.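

Placed ortho to a fluorosulfonyl group, a chloro brings a gain in this assay and not a loss, with a number 0.43 log units higher from compound 2 to compound 3 (beyond the scatter) for this single exchange. The earlier step, a number 0.71 log units higher from compound 1 to compound 2 (beyond the scatter) on removing a chloro from another place on the same ring, ran the opposite way, so the two steps together show that the sign of the chloro exchange on this ring depends on where the chloro sits. Nothing available explains this difference between the two positions.

The compounds shown leave open whether a fluoro, a methyl or a methoxy group ortho to the fluorosulfonyl group would give a similar gain. They also leave open whether the gain from the chloro would persist if a carboxylic acid or a sulfonamide took the place of the fluorosulfonyl group.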